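Cytotoxicity notes on a diaryl amine series

The source may report more compounds than this note shows. Statements on the series, on what has been measured and on what is new or still open speak of the compounds shown alone.

compound 1 `CSCc1ccc(Nc2ncc(Cc3c(F)cccc3F)o2)cc1` — > 100000 nM
compound 2 `Clc1cccc(Cl)c1Cc1nnc(Nc2ccc(COCc3ccoc3)cc2)o1` — 21000 nM
compound 3 `Clc1cccc(Cl)c1Cc1nnc(Nc2ccc(COCc3ccccc3)cc2)o1` — 84000 nM

In an ADME assay on MT2 cells (Homo sapiens) for cytotoxicity, read by MTT assay (on this read-out higher numbers stand for lower toxicity in this test and lower numbers for higher toxicity in this test), compound 1 gives > 100000 nM; this is a limit of the assay and not a number. Compound 2 gives 21000 nM and compound 3 gives 84000 nM. For the measured compounds named here, the only measured step between them is a 4.0-fold higher number from compound 2 to compound 3 (0.60 log units; beyond the scatter). Compound 1 thus stands at the limit of > 100000 nM in this assay, at which 1 of the 3 values shown sits, with compound 2 and compound 3 below it.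

Compound 4 is `N#Cc1ccc(Nc2ncc(Cc3c(F)cccc3F)o2)cc1`. It differs from compound 1 by cyano in place of (methylsulfanyl)methyl on an aromatic carbon. Going by the values given here, no measured step exchanges these two groups: the single step from compound 2 to compound 3 concerns a different exchange on a different core and does not bear on this change. With nothing to guide the direction, no step beyond the scatter is expected, so the estimated step is a number no higher from compound 1 to compound 4 (the limit leaves the size open). For compound 4 the estimate is 100000 nM, expected to fall between 30000 nM and 300000 nM, and a limit rather than a number is again considered likely.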

Compound 4, half-maximal cytotoxic concentration: 7400 nM
Compound 4: the middle estimate sits 14-fold (1.13 log units) above what was measured; the whole stated range lies above it.
By their numbers in this assay, from the lowest: compound 4; then compound 2; then compound 3. At a limit, above all of these: compound 1.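

On the shared core, the group on this aromatic carbon, para to a large group, has a large bearing on the read-out in this assay: cyano in place of (methylsulfanyl)methyl gives an at least 13-fold lower number from compound 1 to compound 4 (1.13 log units; beyond the scatter) and so moves towards higher toxicity in this test. For the compounds shown here, the earlier step concerned the far end of a different core, so this is the first reading for this position. The full size of the step stays open because compound 1 sits at a limit of the assay and not a number: the limit of > 100000 nM in this assay, at which 1 of the 4 values shown sits.

From the compounds shown here alone, whether the change follows from gaining cyano or from losing (methylsulfanyl)methyl remains open, since only these two groups are compared here. Going by these compounds, an amine, a carboxylic acid or a longer chain on this aromatic carbon could separate the two readings, and the same exchange on the core of compound 2 remains untested in these data.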